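Working notes on the series: compound 1 to compound 3

The compounds below may be only part of what the source reports. "The series", "measured", "known", "first", "only" and "open" are said of these compounds alone.

Measured compounds:
compound 1 `COc1cc(C(=O)/C=C/c2cc(-c3cc(OC)c(OC)c(OC)c3)n3nc(-c4ccccc4)cc3n2)cc(OC)c1OC`: 20500 nM
compound 2 `COc1ccc(-c2cc(/C=C/C(=O)c3cc(OC)c(OC)c(OC)c3)nc3cc(-c4ccccc4)nn23)cc1OC`: 7200 nM

In a functional assay on A549 cells (Homo sapiens) for antiproliferative activity, read by MTT assay, with a stated time of 24 h (on this read-out higher numbers stand for weaker inhibition and lower numbers for stronger inhibition), compound 1 gives 20500 nM, the highest of the two numbers shown. Going by the values given here, compound 2 gives 7200 nM in this assay, and the one measured step, a 2.8-fold lower number from compound 1 to compound 2 (0.45 log units; beyond the scatter), is hydrogen in place of methoxy on an aromatic carbon.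

Compound 3 `COc1cc(-c2cc(/C=C/C(=O)c3ccc(C)c(C)c3)nc3cc(-c4ccccc4)nn23)cc(OC)c1OC` has not been measured. It differs from compound 1 by 3,4-dimethylphenyl in place of 3,4,5-trimethoxyphenyl on a carbonyl carbon.

Among the compounds with values here, the measured step concerns a single methoxy on the other aryl group of the shared core; it says nothing about exchanging the whole ring on the carbonyl carbon, and no other step in the set touches that position. Within the data shown here, the series therefore gives no precedent for this change, and the numbers already seen are all weak. The working expectation is that the number for compound 3 is not improved over compound 1, with an estimated step of a 1.5-fold higher number from compound 1 to compound 3 (0.17 log units; within the scatter) and wide uncertainty in either direction. Compound 3 is estimated at 30000 nM in this assay, with a range from 8000 nM to 100000 nM.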

Compound 3, half-maximal inhibitory concentration: 10600 nM
For compound 3 the middle estimate is 2.8-fold (0.45 log units) above the measured one, and the stated range covers the measured number.
By their numbers in this assay, from the lowest: compounds 2, 3 and 1 (each within the scatter of the next, the first and the last beyond it).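

The ring on the carbonyl carbon can be exchanged without a step beyond the scatter: 3,4-dimethylphenyl in place of 3,4,5-trimethoxyphenyl gives, in this assay, a 1.9-fold lower number from compound 1 to compound 3 (0.29 log units; within the scatter). Going by these compounds alone, this is the first reading at this position, and it shows that the 3,4,5-trimethoxyphenyl group is not needed to hold the number at this level, since a ring with 0 hydrogen-bond acceptors reads alongside one with 3 and has fewer heavy atoms. Nothing available explains why the two rings read alike, and the result marks only a tolerated exchange, not a gain at this position.

Still open, going by these compounds, is whether any group on the carbonyl carbon can move the number beyond the scatter, for example a phenyl ring carrying an amine or a carboxylic acid, or a longer alkyl chain in place of the ring. Also open is whether this exchange gives a similar step on the core of compound 2, which carries 3,4-dimethoxyphenyl on the other side, since the two changes have not been read together in the compounds shown here.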